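This account rests on a few compounds, and the source may have more. Where it says the series, first, only, none or still open, it means among the compounds named here.

Compound 1 `COc1ccc(-c2cccc(O)c2)cc1` gives 72 ug/mL in a functional assay on HT-29 cells (Homo sapiens) for cytotoxicity, read by MTT assay, with a stated time of 3 days; on this read-out lower numbers stand for stronger inhibition and higher numbers for weaker inhibition. Compound 3 `Nc1ccc(-c2cccc(O)c2)cc1` carries amino in place of methoxy on an aromatic carbon, and in this assay compound 3 gives 49.3 ug/mL, a step of a 1.5-fold lower number from compound 1 to compound 3 (0.16 log units; within the scatter). Compound 2 `COc1cccc(-c2ccc(O)cc2)c1` has the same atoms as compound 1 joined differently; the difference between the two cores is not broken down here. In this assay compound 2 gives 24 ug/mL, the lowest of the three numbers. Compound 4 `Nc1cccc(-c2ccc(O)cc2)c1` differs from compound 2 by amino in place of methoxy on an aromatic carbon. This is the same kind of change as that from compound 1 to compound 3, not the same: there the amino sits para to a group of 7 heavy atoms, here meta to a group of 7 heavy atoms. Because the step of a 1.5-fold lower number from compound 1 to compound 3 (0.16 log units; within the scatter) stayed within the scatter, compound 4 is expected to show a similarly small step, a 1.4-fold lower number from compound 2 to compound 4 (0.15 log units; within the scatter). Compound 4 is thus estimated at 17 ug/mL, between 8 ug/mL and 40 ug/mL.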

Compound 4, half-maximal inhibitory concentration: 5.4 ug/mL
The estimate for compound 4 lay 3.1-fold (0.50 log units) above the measured number; the measured number lies below the stated range.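

With amino in place of methoxy on an aromatic carbon, this assay shows a 4.4-fold lower number from compound 2 to compound 4 (0.65 log units; beyond the scatter) on this core. The size of the step does not carry over unchanged from one core to the other: the same change on two cores in this assay, a 1.5-fold lower number (0.16 log units; within the scatter) from compound 1 to compound 3 and a 4.4-fold lower number (0.65 log units; beyond the scatter) from compound 2 to compound 4, 3.0-fold (0.48 log units) apart, beyond the scatter of two such steps. These two pairs alone do not show which feature of the cores accounts for the gap, nor how the same change would behave on a further core.

The compounds shown leave open how a dimethylamino group or an acetamide would fare in place of the amino on either core. Also open, as far as these compounds go, is what a carboxylic acid in place of the hydroxyl would do.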